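Replacing a benzyl group with a directly attached aryl ring

The compounds below may be only part of what the source reports. "The series", "measured", "known", "first", "only" and "open" are said of these compounds alone.

Measured compounds:
compound 1, `C=C(Br)C(=O)Nc1cccc(-c2cn3nc(CCc4ccccc4)sc3n2)c1`: 2200 nM
compound 2, `C=C(Br)C(=O)Nc1cccc(-c2cn3nc(-c4ccc(F)cc4)sc3n2)c1`: 250 nM
compound 3, `C=C(Br)C(=O)Nc1cccc(-c2cn3nc(Cc4ccccc4)sc3n2)c1`: 3000 nM

These three compounds share the same core and differ only in the group attached to one aromatic carbon of it. In a functional assay on L1210 cells (Mus musculus) for inhibition, read by cell counting, with a stated time of 2 days (a higher number here means a weaker inhibitor, a lower number a stronger inhibitor), compound 3 gives 3000 nM, the highest of the three numbers. Its nearest neighbour is compound 1, which shows 2200 nM; the gap between them, a 1.4-fold higher number from compound 1 to compound 3 (0.13 log units; within the scatter), is within the scatter. Compound 2, which carries 4-fluorophenyl attached directly to the core, is far apart: the step of a 12-fold higher number from compound 2 to compound 3 (1.08 log units; beyond the scatter) is large, and in the other direction an 8.8-fold lower number from compound 1 to compound 2 (0.94 log units; beyond the scatter) points the same way.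

Compound 4, `C=C(Br)C(=O)Nc1cccc(-c2cn3nc(-c4cccc(OC)c4)sc3n2)c1`, has not been measured. It differs from compound 3 in one place: 3-methoxyphenyl in place of benzyl on an aromatic carbon. Like compound 2, it carries an aromatic ring bound directly to the core rather than through a saturated chain carbon. The step of a 12-fold higher number from compound 2 to compound 3 (1.08 log units; beyond the scatter) is the closest guide, so a large step toward a lower number is expected. That expectation means a 7.5-fold lower number from compound 3 to compound 4 (0.88 log units; beyond the scatter). Compound 4 is therefore estimated to give 400 nM, with a range from 150 nM to 1200 nM.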

Compound 4, half-maximal inhibitory concentration: 580 nM
The estimate for compound 4 lay 1.5-fold (0.16 log units) below the measured number, and the stated range covers the measured number.
By their numbers in this assay, from the lowest: compound 2; then compound 4; then compounds 1 and 3 (each within the scatter of the next).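

In this assay, the lower number seen with the directly attached 4-fluorophenyl of compound 2 now appears with a second aryl group: replacing benzyl with 3-methoxyphenyl gives a 5.2-fold lower number from compound 3 to compound 4 (0.71 log units; beyond the scatter), and replacing phenethyl with it gives a 3.8-fold lower number from compound 1 to compound 4 (0.58 log units; beyond the scatter). The effect at this aromatic carbon is therefore not tied to 4-fluorophenyl alone, yet the two directly attached rings are not interchangeable, since exchanging one for the other gives a 2.3-fold higher number from compound 2 to compound 4 (0.37 log units; beyond the scatter), a gap beyond the scatter. Nothing available here explains the difference between directly attached rings and rings held on a saturated chain, or the difference between the two aryl groups.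

The two aryl groups differ in both the substituent and its place on the ring, so the compounds shown cannot say which of these matters. A 4-methoxyphenyl or 3-fluorophenyl group would separate the two, while an unsubstituted phenyl ring would show what the directly attached ring does without any substituent.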